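Swapping a 3-fluorophenyl Group for 2-chloropyridin-4-yl

A few compounds are considered here, and "the series" means these few. Any claim that something is new, unique, unknown or untested is made for them only; others in the source may bear on it.

Compound 1 `O=C(O)Cc1sc(C2COc3ccccc3O2)nc1-c1ccc(Cl)cc1`: 500 nM
Compound 2 `COc1ccc(OC)c(-c2nc(C(c3ccccc3)c3ccccc3)sc2CC(=O)O)c1`: a limit only, > 105 nM
Compound 3 `O=C(O)Cc1sc(C(c2ccc(F)cc2)c2ccc(F)cc2)nc1-c1cccc(F)c1`: 1.4 nM

All three were tested in an in vitro assay on HEK385-7 cells for displacement of a labelled ligand from prostaglandin D2 receptor 2 (Homo sapiens); a higher number here means a weaker inhibitor, a lower number a stronger inhibitor. Compound 2 reaches only the limit of the assay the limit of > 105 nM in this assay, at which 1 of the 3 values shown sits, and so gives no number of its own. Of the two real numbers, compound 3 has the lower one, and its nearest neighbour is compound 1, whose value sits far higher, well beyond the scatter of repeated measurements. Compound 3 is thus the strongest binder among the numbers shown.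

Compound 4 `O=C(O)Cc1sc(C(c2ccc(F)cc2)c2ccc(F)cc2)nc1-c1ccnc(Cl)c1` has not been measured. It differs from compound 3 in a single place (2-chloropyridin-4-yl in place of 3-fluorophenyl on an aromatic carbon). The rest of the molecule, including the carboxymethyl group and the large group on the other side of the shared core, stays the same.

Among the measured compounds shown here, no measured pair here changes only this one aryl group, so there is no direct precedent. A ring of this kind is often tolerated, but a new nitrogen and a chlorine in place of fluorine can shift binding either way. The expected step in this assay from compound 3 to compound 4 is a 2.9-fold higher number from compound 3 to compound 4 (0.46 log units; beyond the scatter), a small loss, close to the scatter. Compound 4 is therefore estimated at 4 nM, within 1 nM to 20 nM.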

Compound 4, half-maximal inhibitory concentration: 3.1 nM
Compound 4: the middle estimate sits 1.3-fold (0.11 log units) above what was measured, and the stated range covers the measured number.
By their numbers in this assay, from the lowest: compound 3; then compound 4; then compound 1.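

In this assay, replacing 3-fluorophenyl with 2-chloropyridin-4-yl gives a modest but real loss, a 2.2-fold higher number from compound 3 to compound 4 (0.35 log units; beyond the scatter). Among the compounds shown here, this is the first direct reading at this position, on an aromatic carbon next to the ring nitrogen and next to the ring atom that bears the carboxymethyl group: with the rest of the molecule unchanged, a ring with a hetero atom and a hydrogen-bond acceptor can replace the all-carbon ring, and compound 4 still gives 3.1 nM. The compounds shown offer no measurement that explains the size of this step.

As far as these compounds go, the change brings in a ring nitrogen and exchanges fluorine for chlorine in a single step, so the share of each in the loss remains unknown, and 3-chlorophenyl and 2-fluoropyridin-4-yl at this position would be needed to separate the two. From the compounds shown here alone, it also remains open how far this position tolerates a pyridine ring carrying something other than a halogen, such as the amine of 2-aminopyridin-4-yl or the methoxy group of 2-methoxypyridin-4-yl.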